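A Sulfonamide Aryl Swap Awaiting Its Measurement

The source may report more compounds than this note shows. Statements on the series, on what has been measured and on what is new or still open speak of the compounds shown alone.

Three measured compounds set the scene. Compound 1 `O=C(O)COCCCCC1=CCC[C@@H]1NS(=O)(=O)c1ccc(Cl)c(Cl)c1` carries a 3,4-dichlorophenyl group on a sulfonyl sulfur, and in a functional assay on a cell-free system (plasma) for inhibition of thromboxane A2 receptor (Homo sapiens), read by turbidimetry (a lower number here means a stronger inhibitor, a higher number a weaker inhibitor), compound 1 gives 1900 nM. Compound 2 `O=C(O)CCC/C=C\C[C@H]1[C@H](F)CC[C@@H]1NS(=O)(=O)c1ccccc1` gives 1100 nM in this assay, and compound 3 `O=C(O)CC/C=C\CC1=CCC[C@@H]1NS(=O)(=O)c1ccc(F)cc1` gives 1300 nM. Compound 1 has the highest of the three numbers, yet its gaps to compound 3 and to compound 2 both lie within the usual scatter of this kind of measurement, so no real ordering among the three can be drawn from them.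

Compound 4 `O=C(O)COCCCCC1=CCC[C@@H]1NS(=O)(=O)c1ccccc1[N+](=O)[O-]` differs from compound 1 in one place: 2-nitrophenyl in place of 3,4-dichlorophenyl on a sulfonyl sulfur. Among the measured compounds shown here, no measured pair among the three compounds shows what this kind of change does, so the expectation rests on nothing more than the unchanged remainder of the molecule. The step of a 1.3-fold higher number from compound 1 to compound 4 (0.12 log units; within the scatter) is expected to stay within the scatter, with no clear direction. Compound 4 is therefore expected to give 2500 nM in this assay, with a plausible range from 700 nM to 9000 nM.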

Compound 4, half-maximal inhibitory concentration: 1900 nM
Compound 4: the middle estimate sits 1.3-fold (0.12 log units) above what was measured; low and high end bracket the measured number.
By their numbers in this assay, from the lowest: compounds 2, 3, 1 and 4 (each within the scatter of the next).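

Putting 2-nitrophenyl in place of 3,4-dichlorophenyl on a sulfonyl sulfur gives, in this assay, no change at the digits printed from compound 1 to compound 4 (within the scatter). This is the only pair shown that differs in one place, so it gives the first direct reading at this position: with the rest of compound 1 kept, a ring carrying two chlorine atoms and a ring carrying a nitro group, which brings two hydrogen-bond acceptors, read alike. No other measurement shown here offers an explanation for this result.

On these data alone, whether a naphthyl group or an amine-bearing phenyl ring on the sulfonyl sulfur would also read alike remains open. So does whether this same exchange would give a similar result on the core of compound 2 or compound 3.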